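Adding a Second Methoxy Group to an Inactive Scaffold

The compounds below may be only part of what the source reports. "The series", "measured", "known", "first", "only" and "open" are said of these compounds alone.

The shared core carries two methoxy groups and a double bond to a substituted phenyl ring. Compound 1 `COc1ccccc1/C=C1\CCc2cc(OC)c(OC)cc2C1=O` bears a 2-methoxyphenyl there. In a functional assay on Jurkat cells (Homo sapiens) for antiproliferative activity, read by MTT assay (a higher number here means a weaker inhibitor, a lower number a stronger inhibitor), compound 1 gives only a limit of the assay, > 50000 nM. Compound 2 `COc1ccc(/C=C2\CCc3cc(OC)c(OC)cc3C2=O)cc1` bears a 4-methoxyphenyl instead, and in this assay compound 2 likewise gives only a limit, > 50000 nM. The step that the two limits leave unreadable from compound 1 to compound 2 therefore cannot be read; the limit of > 50000 nM in this assay, at which 2 of the 2 values shown sit, describes where both measured values sit. Compound 3 `COc1ccc(/C=C2\CCc3cc(OC)c(OC)cc3C2=O)c(OC)c1` differs from compound 2 by methoxy in place of hydrogen on an aromatic carbon. Among the compounds with values here, no measured step bears directly on this change, and the only measured step is unreadable. Compound 3 is therefore expected to give a value near that limit again, with the step of a number no higher from compound 2 to compound 3 (the limit leaves the size open) estimated to be small. The estimate for compound 3 in this assay is 50000 nM, within a range from 15000 nM to 200000 nM.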

Compound 3, half-maximal inhibitory concentration: > 50000 nM
Compound 3: a limit, no number; the forecaster's own chance of this, stated with the estimate: 70%; the middle value lies on the limit itself.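

In this assay compound 3 gives > 50000 nM as a limit, not a number. Its steps from compound 1 and compound 2 therefore cannot be read: the limit of > 50000 nM in this assay, at which 3 of the 3 values shown sit. From the compounds shown here alone, how strongly each of the three compounds acts, and whether the added methoxy changes that, remains open.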